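Series notes: aryl group added at the ring position

The source may report more compounds than this note shows. Statements on the series, on what has been measured and on what is new or still open speak of the compounds shown alone.

Measured compounds:
compound 1 `CCOC(=O)c1c(-c2cccc(C(F)(F)F)c2)csc1N` — 9.4 uM
compound 2 `Nc1scc(-c2cccc(C(F)(F)F)c2)c1C(=O)c1ccccc1` — 15.8 uM
compound 3 `Nc1sc(-c2ccc(Cl)cc2)c(-c2cccc(C(F)(F)F)c2)c1C(=O)c1ccccc1` — > 10 uM (a limit, not a number)

In a functional assay on CHO-K1 cells for agonist activity at adenosine receptor A1 (Homo sapiens), read by GTPgammaS binding (a lower number here means that less compound is needed, a higher number that more compound is needed for the effect), compound 1 gives 9.4 uM, the lowest of the two numbers shown. Its nearest neighbour is compound 2, at 15.8 uM; the step of a 1.7-fold higher number from compound 1 to compound 2 (0.23 log units; within the scatter) stays within the scatter, so the two are not ordered. Compound 3 reaches only a limit in this assay, > 10 uM. The step that the limit leaves unreadable from compound 2 to compound 3 therefore cannot be sized, because of the limit of > 10 uM in this assay, at which 1 of the 3 values shown sits.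

Compound 4 `CCOC(=O)c1c(N)sc(-c2ccc([N+](=O)[O-])cc2)c1-c1cccc(C(F)(F)F)c1` differs from compound 1 in one place: 4-nitrophenyl in place of hydrogen on an aromatic carbon. Among the compounds with values here, the one measured step that bears on this change is the one from compound 2 to compound 3, where an aryl group entered at the same position; that step is only known to end at a limit. On these data alone, its direction is toward a higher number, its size is unknown. The expectation for compound 4 is therefore a higher number than compound 1, with a fair chance that this assay again reports only a limit, and the step from compound 1 to compound 4 is estimated as a 2.7-fold higher number from compound 1 to compound 4 (0.42 log units; beyond the scatter). For compound 4 the estimate in this assay is 25 uM, with a range from 8 uM to 80 uM.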

Compound 4, concentration for half-maximal effect: > 10 uM
Compound 4: a limit, no number (the forecaster's own chance of this, stated with the estimate: 60%); the middle value does not contradict the limit.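

In this assay compound 4 gives > 10 uM and this is a limit, not a number. The reading is an at least 1.0-fold higher number from compound 1 to compound 4 (0.02 log units; that floor lies within the scatter) and gives only a floor, so compound 1 and compound 4 cannot be ordered, and no loss at this position on the ethoxycarbonyl compound is established. What is new is that an aryl group next to the ring sulfur now ends at a limit with either carbonyl partner, ethoxycarbonyl as well as benzoyl, and neither step can be sized because of the limit: the limit of > 10 uM in this assay, at which 2 of the 4 values shown sit.

Open, on these data alone, is whether a methyl group, a plain phenyl or a morpholine in this place on the core of compound 1 would give a readable number, so that the hydrogen-to-aryl change could be sized at all. Also open, as far as these compounds go, is whether an amine or a carboxylic acid on the 4-position of the entering phenyl would read differently from the nitro group of compound 4, which would show whether the ring itself or its substituent governs this outcome.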